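Swapping a small amine for an aromatic one

The source may report more compounds than this note shows. Statements on the series, on what has been measured and on what is new or still open speak of the compounds shown alone.

Measured in a physicochemical assay for solubility; on this read-out lower numbers stand for lower solubility and higher numbers for higher solubility:
- compound 1 `CC(C)C(=O)N1CCC[C@H]1C(=O)N1CCC(NS(=O)(=O)c2cc(S(=O)(=O)c3ccccc3)ccc2C(F)(F)F)CC1` gives 100000 nM
- compound 2 `CC(C)(C)C(=O)N1CCC[C@H]1C(=O)N1CCC(NS(=O)(=O)c2cc(S(=O)(=O)c3ccccc3)ccc2C(F)(F)F)CC1` gives 50000 nM
- compound 3 `CN(C)CC(=O)N1CCC[C@H]1C(=O)N1CCC(NS(=O)(=O)c2cc(S(=O)(=O)c3ccccc3)ccc2C(F)(F)F)CC1` gives 100000 nM

Compound 3, at 100000 nM, cannot be told apart from the other two compounds. The measured steps are no change at the digits printed from compound 1 to compound 3 (within the scatter) and a 2.0-fold higher number from compound 2 to compound 3 (0.30 log units; within the scatter), both within the scatter.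

Compound 4 `CN(C)c1ccc(C(=O)N2CCC[C@H]2C(=O)N2CCC(NS(=O)(=O)c3cc(S(=O)(=O)c4ccccc4)ccc3C(F)(F)F)CC2)cc1` keeps the core of compound 3 and alters one group: 4-(dimethylamino)phenyl in place of (dimethylamino)methyl on a carbonyl carbon. In words, this puts 4-(dimethylamino)phenyl in place of (dimethylamino)methyl on a carbonyl carbon.

Those two steps bear on this change, since they also swap groups on that carbonyl carbon. So does a 2.0-fold lower number from compound 1 to compound 2 (0.30 log units; within the scatter), again within the scatter. None of them brings in a ring, so they do not settle the size of this step, and the expectation below is a judgement, not a measured trend.

The expected change is a 5.0-fold lower number from compound 3 to compound 4 (0.70 log units; beyond the scatter), a drop beyond the scatter. For compound 4 the estimated value is 20000 nM, with an expected range from 3000 nM to 100000 nM.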

Compound 4, solubility: 100000 nM
The estimate for compound 4 lay 5.0-fold (0.70 log units) below the measured number; measured number inside the range.
By their numbers in this assay, from the lowest: compounds 2, 1, 3 and 4 (each within the scatter of the next).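

In this assay, a six-membered aromatic ring of carbon only now stands on this carbonyl carbon, with 9 heavy atoms entering where 4 leave, yet the step cannot be told from scatter (no change at the digits printed from compound 3 to compound 4 (within the scatter)). The reading is the same against the two other groups, isopropyl (no change at the digits printed from compound 1 to compound 4 (within the scatter)) and tert-butyl (a 2.0-fold higher number from compound 2 to compound 4 (0.30 log units; within the scatter)), so at this place a much larger group with a ring gives no step beyond the scatter among these compounds. No measurement here offers an explanation for this result.

Still open, going by these compounds, is whether the dimethylamino group on the ring matters, which a plain phenyl group on the same carbonyl carbon would test. A carboxylic acid on that ring, or a longer chain ending in an amine, could also show whether any group at this place gives a step beyond the scatter.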